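Imidazole Replaces Dimethylamine on the Propyl Chain

A few compounds are considered here, and "the series" means these few. Any claim that something is new, unique, unknown or untested is made for them only; others in the source may bear on it.

compound 1 `CN1CCN(CCCn2nc(C3=C(c4cn(C)c5ccccc45)C(=O)NC3=O)c3cccnc32)CC1` — > 100000 nM
compound 2 `CN(C)CCCn1nc(C2=C(c3cn(C)c4ccccc34)C(=O)NC2=O)c2cccnc21` — > 100000 nM

In a functional assay on A549 cells (Homo sapiens) for antiproliferative activity, read by MTT assay, with a stated time of 48 h (on this read-out lower numbers stand for stronger inhibition and higher numbers for weaker inhibition), compound 1 gives > 100000 nM, which is a limit of the assay rather than a number. Compound 2 gives > 100000 nM, likewise a limit. The step that the two limits leave unreadable from compound 1 to compound 2 is therefore unreadable, and compound 2 stands at the limit of > 100000 nM in this assay, at which 2 of the 2 values shown sit. Compound 3 `Cn1cc(C2=C(c3nn(CCCCn4ccnc4)c4ncccc34)C(=O)NC2=O)c2ccccc21` differs from compound 2 by (1H-imidazol-1-yl)methyl in place of dimethylamino on a saturated chain carbon, three bonds along the chain from an aromatic nitrogen. Within the data shown here, no measured step gives a readable size, so none points in a direction. Compound 3 is expected to remain near the limit, and the step of a number no higher from compound 2 to compound 3 (the limit leaves the size open) is expected to be small. Compound 3 is estimated at 100000 nM, between 30000 nM and 300000 nM.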

Compound 3, half-maximal inhibitory concentration: 2380 nM
For compound 3 the middle estimate is 42-fold (1.62 log units) above the measured one; the whole stated range lies above it.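

The earlier compounds shown here gave no readable value at this position, only a limit: the limit of > 100000 nM in this assay, at which 2 of the 3 values shown sit. In this assay, the chain position proves able to carry a measurable effect: (1H-imidazol-1-yl)methyl in place of dimethylamino gives an at least 42-fold lower number from compound 2 to compound 3 (1.62 log units; beyond the scatter), and the same group in place of 4-methylpiperazin-1-yl gives an at least 42-fold lower number from compound 1 to compound 3 (1.62 log units; beyond the scatter). The change from 3-(dimethylamino)propyl to 4-(1H-imidazol-1-yl)butyl alters both the end group and the chain, so the compounds shown do not separate the two. A 3-(1H-imidazol-1-yl)propyl or 4-(dimethylamino)butyl chain would be needed to tell them apart.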